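Cytotoxicity notes on the shared core: benzyl-side nitrile variants

The compounds below may be only part of what the source reports. "The series", "measured", "known", "first", "only" and "open" are said of these compounds alone.

Compound 1, `CC(C)=CCN1C(=O)N(Cc2ccccc2)S(=O)(=O)n2cccc21`, is the reference for this step. In an ADME assay on MT4 cells (Homo sapiens) for cytotoxicity, read by MTT assay, with a stated time of 5 days (on this read-out lower numbers stand for higher toxicity in this test and higher numbers for lower toxicity in this test), compound 1 gives 226000 nM. Compound 3, `N#CCN1C(=O)N(Cc2cccc(F)c2)S(=O)(=O)n2cccc21`, gives 172000 nM in this assay, and this value and that of compound 1 lie within the usual scatter of one another, so no order between them is claimed. Compound 2, `N#Cc1ccccc1CN1C(=O)N(Cc2cccc(F)c2)S(=O)(=O)n2cccc21`, reaches only a limit of the assay, > 305000 nM, and not a number. Compound 4, `N#Cc1cccc(CN2C(=O)N(Cc3ccccc3)S(=O)(=O)n3cccc32)c1`, is not yet measured in this assay.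

The change from compound 1 to compound 4 is 3-cyanophenyl in place of 2-methylprop-1-en-1-yl on a saturated chain carbon bound to an amide-type nitrogen in a ring. Within the data shown here, the single measured step that bears on it, an at least 1.7-fold lower number from compound 2 to compound 3 (0.24 log units; that floor lies within the scatter), removes a cyanophenyl group from the same place and concerns only the lower end of a limit; its floor sits within the scatter. Among the measured compounds shown here, it thus gives no evidence that a cyanophenyl group at this place shifts the half-maximal cytotoxic concentration beyond the scatter, and there is no measured pair that exchanges the 2-methylprop-1-en-1-yl group directly.

For compound 4 the step is therefore expected to be a 1.1-fold higher number from compound 1 to compound 4 (0.03 log units; within the scatter), that is, nothing beyond the scatter. Compound 4 is expected to give about 240000 nM, with a range from 120000 nM to 480000 nM, and a fair chance that only a limit is reported, as for compound 2 with the limit of > 305000 nM in this assay, at which 1 of the 3 values shown sits.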

Compound 4, half-maximal cytotoxic concentration: > 318000 nM
Compound 4 was reported as a limit; the forecaster's own chance of this, stated with the estimate: 35%; middle value at least 1.3-fold (0.12 log units) away from the limit.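

Among these compounds, compound 4 gives the first direct exchange at this place, 3-cyanophenyl in place of 2-methylprop-1-en-1-yl on a saturated chain carbon bound to an amide-type nitrogen in a ring, and in this assay it reads as an at least 1.4-fold higher number from compound 1 to compound 4 (0.14 log units; that floor lies within the scatter). Compound 4 is reported only as a limit, > 318000 nM, and not as a number. Among the compounds shown, compound 2 with 2-cyanophenyl and compound 4 with 3-cyanophenyl are the two that carry a cyanophenyl group at this place and the two that end in a limit, while compound 1 and compound 3 give numbers, so the link seen once in compound 2 now holds for a second nitrile arrangement and on a benzyl side without fluorine.

The compounds shown leave open how far compound 2 and compound 4 lie from their limits, so no order between those two can be read. They also leave open whether an amine, a carboxylic acid or a longer chain on this carbon would stay within the scatter of compound 1 or move the half-maximal cytotoxic concentration beyond it.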